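Swapping fluoro for chloro on the aromatic side chain

The compounds below may be only part of what the source reports. "The series", "measured", "known", "first", "only" and "open" are said of these compounds alone.

Of the compounds shown here, three that share one core have been measured in an in vitro ADME assay on the whole organism (microsomes, liver, Mus musculus) for metabolic stability, read by LC-MS, with a stated time of 24 h, at a dose of 5 mg/kg by the intravenous route; a lower number here means slower removal, a higher number faster removal of the compound. Compound 1 `O=[N+]([O-])c1cn2c(n1)OC[C@@H](NCc1ccc(OC(F)(F)F)cc1F)C2` gives 95.6 mL.min-1.g-1 in this assay, compound 3 `O=[N+]([O-])c1cn2c(n1)OC[C@@H](NCc1ccc(OC(F)(F)F)cc1Cl)C2` gives 69.7 mL.min-1.g-1, and compound 2 `O=[N+]([O-])c1cn2c(n1)OC[C@@H](NCc1ccc(OC(F)(F)F)c(F)c1)C2` gives 58.7 mL.min-1.g-1. Compound 1 and compound 3 differ in a single place: chloro in place of fluoro on an aromatic carbon. The step that went with this change was a 1.4-fold lower number from compound 1 to compound 3 (0.14 log units; within the scatter). Compound 2 is built from the same atoms as compound 1, joined differently; the difference between these two cores is not broken down here. All three values lie close together, and none of the gaps between them reaches beyond the usual scatter of repeated measurements, so no order among them can be claimed.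

Compound 4 `O=[N+]([O-])c1cn2c(n1)OC[C@@H](NCc1ccc(OC(F)(F)F)c(Cl)c1)C2` has not yet been measured. It differs from compound 2 by chloro in place of fluoro on an aromatic carbon. The surroundings are not those of the earlier change: there the chloro entered ortho to a large group and meta to a trifluoromethoxy group, here it enters ortho to a trifluoromethoxy group and meta to a large group, so this is the same kind of change, not the same change. The step expected in this assay is a 1.2-fold lower number from compound 2 to compound 4 (0.07 log units; within the scatter), resting on the earlier step of a 1.4-fold lower number from compound 1 to compound 3 (0.14 log units; within the scatter), which stayed within the scatter. Compound 4 is therefore expected to give about 50 mL.min-1.g-1, most likely between 28 mL.min-1.g-1 and 90 mL.min-1.g-1.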

Compound 4, intrinsic clearance in microsomes in the liver assay: 103 mL.min-1.g-1
For compound 4 the middle estimate is 2.1-fold (0.31 log units) below the measured one, and the stated range ends below it.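

In the liver assay, compound 2 gives 58.7 mL.min-1.g-1 and compound 4 gives 103 mL.min-1.g-1. In the liver assay, chloro in place of fluoro went with a 1.8-fold higher number from compound 2 to compound 4 (0.24 log units; within the scatter), so on this core, as on the core of compound 1, the change cannot be told apart from the spread of repeated measurements. Set side by side, the two steps do not differ by more than such steps can scatter: the same change on two cores in the liver assay, a 1.4-fold lower number (0.14 log units; within the scatter) from compound 1 to compound 3 and a 1.8-fold higher number (0.24 log units; within the scatter) from compound 2 to compound 4, 2.4-fold (0.38 log units) apart, within the scatter of two such steps. This gives no rule in either sense, since two pairs cannot show that the swap has no effect, nor that it carries from one core to the other by a set amount. In a physicochemical assay for solubility, at pH 6.8 (on this read-out lower numbers stand for lower solubility and higher numbers for higher solubility), compound 2 gives 43 ug/mL and compound 4 gives 77 ug/mL. Among the compounds shown here, the single step in the physicochemical assay, a 1.8-fold higher number from compound 2 to compound 4 (0.25 log units; within the scatter), likewise stays within the scatter.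

The compounds shown leave open whether other groups in the same place on the aromatic ring, such as bromo, methyl or a nitrile, would give steps large enough to stand clear of the scatter on either core. Also open, going by these compounds, is whether the swap would read the same with a carboxylic acid or a longer chain on the side-chain nitrogen.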